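The source may report more compounds than this note shows. Statements on the series, on what has been measured and on what is new or still open speak of the compounds shown alone.

Compound 1, `COc1ccc(-c2cccc(COc3ccc4c(c3)CN(C3CCCC3)C4=O)c2)cc1C(=O)O`, is tested in an ADME assay on a cell-free system (plasma, Rattus norvegicus) for metabolic stability, read by LC-MS, with a stated time of 1 h, at 37 degrees C, tested at 100 uM (on this read-out higher numbers stand for a more stable compound and lower numbers for a less stable compound), where compound 1 gives 100%. Two other compounds were run in the same way: compound 2, `CN(C)C(=O)c1cc(-c2cccc(COc3ccc4c(=O)n(C5CCCC5)sc4c3)c2)ccc1Cl`, gives 100%, and compound 3, `O=C(O)c1cc(-c2cccc(COc3ccc4c(=O)n(CC5CC5)sc4c3)c2)ccc1Cl`, gives 100%. On these numbers compound 1 stands level with compound 2 and with compound 3; none of the three is told apart from the others, as every gap lies within the scatter of repeated runs.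

The next compound to be measured in this assay is compound 4, `O=C(O)c1ccc(Cl)c(-c2cccc(COc3ccc4c(c3)CN(C3CCCC3)C4=O)c2)c1`. It keeps the core of compound 1 and differs in one group on an aromatic carbon: 5-carboxy-2-chlorophenyl in place of 3-carboxy-4-methoxyphenyl on an aromatic carbon.

Going by the values given here, no step between two measured compounds is available to show how such a change moves the read-out. With every measured compound sitting at the same full value, the expected step for compound 4 is none beyond the scatter, that is no change at the digits printed from compound 1 to compound 4 (within the scatter). Compound 4 is therefore estimated to give 100% in this assay, with a range from 90% to 100%.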

Compound 4, percent of the compound remaining: 100%
For compound 4 middle estimate and measured number coincide at the digits printed, within the range that was stated.
By their numbers in this assay, from the lowest: compounds 1, 2, 3 and 4 (each within the scatter of the next).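

In this assay, putting 5-carboxy-2-chlorophenyl in place of 3-carboxy-4-methoxyphenyl on an aromatic carbon gives no change at the digits printed from compound 1 to compound 4 (within the scatter). Going by these compounds alone, this is the first pair that differs in one place, and it shows that this exchange of one carboxy-bearing phenyl group for another, on the core of compound 1, leaves the read-out at its full value, so any loss from the change stays within the scatter. Nothing at hand explains why the read-out holds at this value.

All the compounds shown carry either a carboxylic acid or a dimethylamide on this outer phenyl ring, and all sit at the same full value. As far as these compounds go, whether a methyl ester or a primary amine in that role would also stay there remains open.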